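Methanesulfonamido to acetamido on the side chain

The source may report more compounds than this note shows. Statements on the series, on what has been measured and on what is new or still open speak of the compounds shown alone.

In a functional assay on RKO cells (Homo sapiens) for cytotoxicity, read by MTT assay, with a stated time of 5 days (a higher number here means a weaker inhibitor, a lower number a stronger inhibitor), compound 1 `CCOc1cc(C(C)(C)C)ccc1C1=N[C@@](C)(c2ccc(Cl)cc2)[C@@](C)(c2ccc(Cl)cc2)N1C(=O)N1CCN(CCC(F)(F)F)CC1` gives 400 nM and compound 2 `CCOc1cc(C(C)(C)C)ccc1C1=N[C@@](C)(c2ccc(Cl)cc2)[C@@](C)(c2ccc(Cl)cc2)N1C(=O)N1CCN(CCNS(C)(=O)=O)CC1` gives 300 nM. Going by the values given here, these are the only two numbers so far, and they lie within the scatter of each other, so compound 2 stands level with compound 1.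

Compound 3 `CCOc1cc(C(C)(C)C)ccc1C1=N[C@@](C)(c2ccc(Cl)cc2)[C@@](C)(c2ccc(Cl)cc2)N1C(=O)N1CCN(CCNC(C)=O)CC1` has acetyl in place of methylsulfonyl on an amine nitrogen, and the core of compound 1 is unchanged: acetyl in place of methylsulfonyl on an amine nitrogen. Cut one bond further out, the same difference reads methanesulfonamido to acetamido.

Among the compounds with values here, only one measured step bears on this change: a 1.3-fold lower number from compound 1 to compound 2 (0.12 log units; within the scatter). It introduced the methanesulfonamido group in place of trifluoromethyl, and its size stayed within the scatter. Within the data shown here, no measured step covers the acetamido group itself, so this is indirect evidence. On that basis, no step beyond the scatter is expected in this assay, and no direction can be assigned with confidence. The expected move is a 1.1-fold higher number from compound 2 to compound 3 (0.04 log units; within the scatter), which remains within the scatter. For compound 3 the estimated value is 330 nM, with an expected range of 160 nM to 700 nM.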

Compound 3, half-maximal inhibitory concentration: 300 nM
Compound 3: the middle estimate sits 1.1-fold (0.04 log units) above what was measured; the range from low to high includes it.
By their numbers in this assay, from the lowest: compounds 2, 3 and 1 (each within the scatter of the next).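

In this assay, going by these compounds alone, acetyl and methylsulfonyl on the amine nitrogen read alike, and no change at the digits printed from compound 2 to compound 3 (within the scatter) is the first direct comparison of these two groups at this position. Against the trifluoromethyl chain end, the 2-acetamidoethyl side chain shows a 1.3-fold lower number from compound 1 to compound 3 (0.12 log units; within the scatter) and so stands level with it, as the 2-(methanesulfonamido)ethyl side chain does, which means that none of the three chain ends shown separates from the others beyond the scatter. No measurement on these compounds accounts for this level reading.

Still open, from the compounds shown here alone, is whether a free primary amine, a carboxylic acid or a longer chain at this position would give a number beyond the scatter of these three compounds. A urea or a tertiary amide in place of the acetamido group would also show whether the amide hydrogen counts for anything in this series, a question that compound 2 and compound 3 cannot answer because both carry that hydrogen.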